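Aryl hydrazones on the benzothiazole-phenyl core: thiophene to hydroxyphenyl

The source may report more compounds than this note shows. Statements on the series, on what has been measured and on what is new or still open speak of the compounds shown alone.

Compound 1 `O=C(N/N=C/c1cccs1)c1ccc(-c2nc3ccccc3s2)cc1` gives 8480 nM in an assay on isolated protein for inhibition of Maltase-glucoamylase (Homo sapiens), with a stated time of 15 min (a higher number here means a weaker inhibitor, a lower number a stronger inhibitor), the second highest of three numbers. Compound 2 `O=C(N/N=C/c1ccc([N+](=O)[O-])cc1)c1ccc(-c2nc3ccccc3s2)cc1` gives 26400 nM; compound 3 `O=C(N/N=C/c1ccc(Cl)cc1)c1ccc(-c2nc3ccccc3s2)cc1` gives 5310 nM. Exchanging the thiophen-2-yl of compound 1 for an aryl gave a 3.1-fold higher number from compound 1 to compound 2 (0.49 log units; beyond the scatter) and a 1.6-fold lower number from compound 1 to compound 3 (0.20 log units; within the scatter), and between the two aryls a 5.0-fold lower number from compound 2 to compound 3 (0.70 log units; beyond the scatter). Compound 4 `O=C(N/N=C/c1cccc(O)c1)c1ccc(-c2nc3ccccc3s2)cc1` carries a 3-hydroxyphenyl: 3-hydroxyphenyl in place of thiophen-2-yl on a carbon with a double bond to nitrogen. It bears on the same change of ring as compound 2 and compound 3, with a hydroxyl instead of nitro or chloro. Compound 4 is therefore expected to land near compound 1, with a 1.1-fold lower number from compound 1 to compound 4 (0.05 log units; within the scatter). Compound 4 is estimated at 7500 nM, between 3000 nM and 20000 nM.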

Compound 4, half-maximal inhibitory concentration: 9210 nM
Compound 4: middle estimate off by 1.2-fold (0.09 log units), on the low side, within the range that was stated.
By their numbers in this assay, from the lowest: compounds 3, 1 and 4 (each within the scatter of the next); then compound 2.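

On this carbon, 3-hydroxyphenyl brings a hydrogen-bond donor that thiophen-2-yl lacks, yet in this assay the exchange gives a 1.1-fold higher number from compound 1 to compound 4 (0.04 log units; within the scatter) and the exchange for 4-chlorophenyl gives a 1.7-fold higher number from compound 3 to compound 4 (0.24 log units; within the scatter) – so the hydroxyl aryl, the chloro aryl and the thiophene cannot be told apart here. Only the 4-nitrophenyl compound stands apart, with a 2.9-fold lower number from compound 2 to compound 4 (0.46 log units; beyond the scatter) – in line with its steps to compound 1 and compound 3. Nothing measured accounts for these steps. Still open, going by these compounds, is how an amine or a carboxylic acid on the aryl ring would read in this assay against the hydroxyl of compound 4.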